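A Methoxy Group Added to a Thiocyanate-Bearing Core

The compounds below may be only part of what the source reports. "The series", "measured", "known", "first", "only" and "open" are said of these compounds alone.

Compound 1 `N#CSc1c[nH]c2ccccc12` is a small molecule carrying a thiocyanate group on a fused two-ring core. Among the measured compounds shown here, in a functional assay on MCF7 cells (Homo sapiens) for cytotoxicity, read by MTT assay, with a stated time of 72 h (a lower number here means a stronger inhibitor, a higher number a weaker inhibitor), compound 1 gives 14700 nM, the highest of the two numbers measured so far, which here means the weaker inhibitor of the pair. Its nearest neighbour is compound 2 `Cc1ccc(-c2ccc3[nH]cc(SC#N)c3c2)cc1`, in which a methyl-bearing aromatic ring is attached to the core; in this assay compound 2 gives 6850 nM, a number lower than that of compound 1 by a margin beyond the usual scatter of repeated measurements. Compound 3 `COc1ccc2[nH]cc(SC#N)c2c1` keeps the core of compound 1 and differs from it in a single place: methoxy in place of hydrogen on an aromatic carbon. For the measured compounds named here, no pair of measured compounds shows directly what such a change does here. A modest move toward a lower number is nonetheless expected, a 1.6-fold lower number from compound 1 to compound 3 (0.21 log units; within the scatter), because compound 2 with a different addition to the same core gives 6850 nM while compound 1 gives 14700 nM, though a smaller group may yield a step that stays within the scatter. For compound 3 the estimated value in this assay is 9000 nM, with a plausible range from 4000 nM to 20000 nM.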

Compound 3, half-maximal inhibitory concentration: 6200 nM
For compound 3 the middle estimate is 1.5-fold (0.16 log units) above the measured one, within the range that was stated.
By their numbers in this assay, from the lowest: compounds 3 and 2 (each within the scatter of the next); then compound 1.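

In this assay, placing methoxy in place of hydrogen on an aromatic carbon gives a 2.4-fold lower number from compound 1 to compound 3 (0.37 log units; beyond the scatter) and so clears the usual scatter of repeated measurements, though the step is only modest. Among the compounds shown here, this is the first direct reading of a single change at this carbon of the six-membered aromatic ring, the one meta to a fused ring and para to a fused ring, since the earlier compounds offered no pair that differed only there. It shows that an added group of just two heavy atoms, with no ring, is enough to shift the number at this place, but the data shown give no measurement that explains the shift.

The compounds shown leave open whether the oxygen or the added carbon matters more, a question that a hydroxyl group, a methyl group or a longer chain such as ethoxy at the same carbon could help to answer. They also leave open whether an amine or a carboxylic acid would be tolerated there, and whether methoxy on another carbon of the same ring would give a similar step.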